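Second methoxy on the anilino ring of a diaminopyrimidine pair

This account rests on a few compounds, and the source may have more. Where it says the series, first, only, none or still open, it means among the compounds named here.

Measured so far:
compound 1, `CCNc1cc(Nc2cccc(Cl)c2)ncn1`
compound 2, `COc1cccc(Nc2cc(Nc3ccc(S(N)(=O)=O)cc3)ncn2)c1`

In an assay for inhibition of Receptor tyrosine-protein kinase erbB-3 variant L858R (Homo sapiens), read by mobility shift assay, with a stated time of 10 min (on this read-out lower numbers stand for stronger inhibition and higher numbers for weaker inhibition), compound 1 reaches only the assay limit, > 10000 nM; this is a limit, not a number. Among the measured compounds shown here, in the same setting compound 2 gives 1850 nM, the only numerical value in the set, so compound 2 stands as the sole reference point. Compound 3, `COc1ccc(OC)c(Nc2cc(Nc3ccc(S(N)(=O)=O)cc3)ncn2)c1`, is not yet measured; it differs from compound 2 by methoxy in place of hydrogen on an aromatic carbon. For the measured compounds named here, no step between measured compounds exists to calibrate this change, so a shift not clearly beyond the scatter is expected, a 1.2-fold lower number from compound 2 to compound 3 (0.09 log units; within the scatter). Compound 3 is therefore estimated at 1500 nM, between 500 nM and 5000 nM.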

Compound 3, half-maximal inhibitory concentration: 619 nM
Beside the measured number, compound 3's estimate is 2.4-fold (0.38 log units) above it; the range from low to high includes it.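

Methoxy in place of hydrogen, ortho to a large group and para to a methoxy group, gives a 3.0-fold lower number from compound 2 to compound 3 (0.48 log units; beyond the scatter) in this assay and is the first change in the series with a measured size. This position therefore accepts a substituent, and the added methoxy is not neutral here. Nothing shown accounts for the gain.

As far as these compounds go, whether the gain is specific to methoxy or would also come with a fluorine, a hydroxyl or an ethoxy stays open. So does whether it would persist without the existing methoxy, or with an amine at this position.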